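A few compounds are considered here, and "the series" means these few. Any claim that something is new, unique, unknown or untested is made for them only; others in the source may bear on it.

Compound 3 `c1coc(CNCCCNc2ccnc3cc(CC4CCCCC4)ccc23)c1` gives 23 10^-6 cm/s in an ADME assay for permeability, using PAMPA, with a stated time of 30 min, at pH 7.4; on this read-out lower numbers stand for lower permeability and higher numbers for higher permeability. Compound 1 `CC(C)CCc1ccc2c(NCCCNCc3ccco3)ccnc2c1` gives 23 10^-6 cm/s in this assay, and compound 3 stands level with it at the digits shown, the two together giving the lowest numbers of the three measured; the pair differ only in that no change at the digits printed from compound 1 to compound 3 (within the scatter). Compound 2 `FC(F)(F)c1ccc(-c2ccc3c(NCCCNCc4ccco4)ccnc3c2)cc1` gives 237 10^-6 cm/s in this assay, the highest of the three, and compound 3 sits furthest from it. Compound 4 `COc1cccc(Oc2ccc3c(NCCCNCc4ccco4)ccnc3c2)c1` has not yet been measured in this assay. Its structure differs from that of compound 3 in one place: 3-methoxyphenoxy in place of cyclohexylmethyl on an aromatic carbon.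

Among the measured compounds shown here, two measured steps bear on this change, both replacing one group on the same aromatic carbon of the shared core. The step of a 10-fold higher number from compound 1 to compound 2 (1.01 log units; beyond the scatter) was large, and the step of a 10-fold lower number from compound 2 to compound 3 (1.01 log units; beyond the scatter) was equally large in the other direction, so exchanging a saturated group for an aromatic one at this position has so far moved the number far beyond the scatter. For the measured compounds named here, the group entering compound 4, however, is not the one present in compound 2, so a rise of smaller size is expected: for the step of a 3.5-fold higher number from compound 3 to compound 4 (0.54 log units; beyond the scatter) the number is estimated to go up. Compound 4 is therefore expected to give about 80 10^-6 cm/s in this assay, with a likely range from 25 10^-6 cm/s to 250 10^-6 cm/s.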

Compound 4, apparent permeability: 317 10^-6 cm/s
For compound 4 the middle estimate is 4.0-fold (0.60 log units) below the measured one, outside the stated range (above it).
By their numbers in this assay, from the lowest: compounds 1 and 3 (each within the scatter of the next); then compounds 2 and 4 (each within the scatter of the next).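

The step of a 14-fold higher number from compound 3 to compound 4 (1.14 log units; beyond the scatter) in this assay shows that a large rise at this aromatic carbon is not confined to the 4-(trifluoromethyl)phenyl group of compound 2, and the step of a 14-fold higher number from compound 1 to compound 4 (1.14 log units; beyond the scatter) shows the same rise when 3-methoxyphenoxy takes the place of isopentyl. The step of a 1.3-fold higher number from compound 2 to compound 4 (0.13 log units; within the scatter) stays within the scatter, so these two quite different aromatic groups, one of them carrying hydrogen-bond acceptors and the other none, give numbers that cannot be told apart; among these four compounds, those with an aromatic ring in the group at this carbon stand apart from those with isopentyl or cyclohexylmethyl, and none goes against this. Nothing given here accounts for this split.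

From the compounds shown here alone, what remains open is whether a plain phenyl group would reach the same level, since compound 2 and compound 4 differ both in the group on their aromatic ring and in how that ring is attached to the core. Going by these compounds, it is also open how far the level would hold with a more strongly charged group at this carbon, such as an amine or a carboxylic acid.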